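The compounds below may be only part of what the source reports. "The series", "measured", "known", "first", "only" and "open" are said of these compounds alone.

Working notes on the series. Among the compounds with values here, in a functional assay on KB-VIN cells (Homo sapiens) for cytotoxicity, read by sulforhodamine B assay (on this read-out higher numbers stand for an effect only at larger amounts of compound and lower numbers for an effect already at smaller amounts), compound 1 (`CC1=C(O)c2c(oc(-c3ccccc3C)cc2=O)C(C)(C)C1=O`) gives 1.75 ug/mL, the lower of the two numbers measured so far. Compound 2 (`CC1=C(O)c2c(oc(-c3c(C)cc(C)cc3C)cc2=O)C(C)(C)C1=O`) gives 5.82 ug/mL, a gap beyond the usual scatter, so compound 1 holds the better position of this pair.

Compound 3 (`CCc1ccc(-c2cc(=O)c3c(o2)C(C)(C)C(=O)C(C)=C3O)cc1`) is still to be measured in this assay. Relative to compound 1 it carries 4-ethylphenyl in place of 2-methylphenyl on an aromatic carbon, next to the ring oxygen, with the rest of the core unchanged (4-ethylphenyl in place of 2-methylphenyl on an aromatic carbon).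

Within the data shown here, no measured compound carries 4-ethylphenyl, and no measured pair isolates this change, so the expectation rests on two values only. Compound 2 at 5.82 ug/mL shows that the number can move beyond the scatter within this small set, so a wide range is kept. A small rise that stays within the scatter is expected, and the estimated step is a 1.4-fold higher number from compound 1 to compound 3 (0.15 log units; within the scatter). The expected value for compound 3 is 2.5 ug/mL, with an estimated range from 0.9 ug/mL to 7 ug/mL.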

Compound 3, concentration for half-maximal effect: 1.54 ug/mL
Compound 3: middle estimate off by 1.6-fold (0.21 log units), on the high side; measured number inside the range.
By their numbers in this assay, from the lowest: compounds 3 and 1 (each within the scatter of the next); then compound 2.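

In this assay, within the data shown here, 4-ethylphenyl in place of 2-methylphenyl on the aromatic carbon next to the ring oxygen gives a step within the scatter (a 1.1-fold lower number from compound 1 to compound 3 (0.06 log units; within the scatter)), the first step that isolates a single exchange at this position; the shared core tolerates both of these substituted phenyl groups here without a readable difference. Among these compounds, the exchange alters the alkyl group and its place on the phenyl ring at once, so the result shows only that the two changes taken together leave the number unresolved from that of compound 1, and it cannot assign anything to either change alone. Nothing available explains this outcome.

The compounds shown leave open what 4-methylphenyl or 2-ethylphenyl would give at this position, and these two groups would separate the alkyl group from its place on the phenyl ring. Also open, going by these compounds, is how far this tolerance extends, for example to a longer chain such as 4-butylphenyl, or to a phenyl ring carrying an amine or a carboxylic acid.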